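This account rests on a few compounds, and the source may have more. Where it says the series, first, only, none or still open, it means among the compounds named here.

In a functional assay on U-251 cells (Homo sapiens) for cytotoxicity, read by sulforhodamine B assay, with a stated time of 48 h, tested at 100 nM (a lower number here means a stronger effect, a higher number a weaker effect of the compound at the concentration tested), compound 3 `COc1cc(C)cc(-c2nn(CC#N)cc2-c2ccnc(-c3ccc(N(C)C)cc3)c2)c1` gives 16%, the lowest of the three numbers in hand. Compound 2 `Cc1cc(O)cc(-c2nn(CC#N)cc2-c2ccnc(-c3ccc(Oc4ccccc4)cc3)c2)c1` gives 88% and compound 1 `COc1cc(C)cc(-c2c(-c3ccnc(-c4ccc(C(C)=O)cc4)c3)cnn2CC#N)c1` gives 89%; both stand beyond the scatter above compound 3, while compound 1 and compound 2 sit within the scatter of each other. For the measured compounds named here, no pair of measured compounds differs in a single place, so no measured step guides the next change. Compound 4 `Cc1cc(O)cc(-c2nn(CC#N)cc2-c2ccnc(-c3ccc(N(C)C)cc3)c2)c1` differs from compound 3 by hydrogen in place of methyl on an oxygen on an aromatic ring. The step is expected to be small, in the direction of a higher number, as a number 9 percentage points higher from compound 3 to compound 4 (within the scatter). Compound 4 is estimated at 25%, with a range from 8% to 55%, because compound 3 gives 16% and the change is confined to the oxygen substituent.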

Compound 4, a percentage reported as activity, at one concentration (the size of the read-out at that concentration, not a potency): 91%
Estimate against measurement, compound 4: 66 percentage points below, outside the stated range (above it).
By their numbers in this assay, from the lowest: compound 3; then compounds 2, 1 and 4 (each within the scatter of the next).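

In this assay, for the compounds shown here, methoxy to hydroxy on an aromatic ring gives the first single change that can be read, and it is large: a number 75 percentage points higher from compound 3 to compound 4 (beyond the scatter). With hydroxy in place, dimethylamino in place of phenoxy on an aromatic carbon stays within the scatter, a number 3 percentage points higher from compound 2 to compound 4 (within the scatter), so dimethylamino alone does not bring the low number of compound 3. Nothing at hand bears on the cause of the large step. Still open, going by these compounds, is whether ethoxy or an amine in place of methoxy keeps that low number.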